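Aryl replacement on the carbon double-bonded to nitrogen

The compounds below may be only part of what the source reports. "The series", "measured", "known", "first", "only" and "open" are said of these compounds alone.

Going by the values given here, in a functional assay on A549 cells (Homo sapiens) for cytotoxicity, read by MTT assay, with a stated time of 72 h (on this read-out lower numbers stand for stronger inhibition and higher numbers for weaker inhibition), compound 1 `O=C(N/N=C/c1cccc(Br)c1)Nc1cc2c(Nc3ccc(F)c(Cl)c3)ncnc2cc1O[C@H]1CCOC1` gives 10700 nM, the lowest of the three numbers measured so far. Compound 2 `N#Cc1ccc(/C=N/NC(=O)Nc2cc3c(Nc4ccc(F)c(Cl)c4)ncnc3cc2O[C@H]2CCOC2)cc1` gives 29100 nM and compound 3 `O=C(N/N=C/c1ccc(F)cc1Cl)Nc1cc2c(Nc3ccc(F)c(Cl)c3)ncnc2cc1O[C@H]1CCOC1` gives 27200 nM; the step of a 2.7-fold higher number from compound 1 to compound 2 (0.43 log units; beyond the scatter) and the step of a 2.5-fold higher number from compound 1 to compound 3 (0.41 log units; beyond the scatter) both run upward beyond the scatter, whereas a 1.1-fold lower number from compound 2 to compound 3 (0.03 log units; within the scatter) stays within it. Compound 4 `CCN(CC)c1ccc(/C=N/NC(=O)Nc2cc3c(Nc4ccc(F)c(Cl)c4)ncnc3cc2O[C@H]2CCOC2)c(O)c1` is not yet measured; it differs from compound 1 by 4-(diethylamino)-2-hydroxyphenyl in place of 3-bromophenyl on a carbon with a double bond to nitrogen. The two measured steps that bear on a change at the carbon with a double bond to nitrogen, a 2.7-fold higher number from compound 1 to compound 2 (0.43 log units; beyond the scatter) and a 2.5-fold higher number from compound 1 to compound 3 (0.41 log units; beyond the scatter), are modest and point the same way, so a modest upward step in this assay is expected for compound 4 as well, though the entering group resembles neither of the two already tried and the range is therefore kept wide. For compound 4 the expected value is 22000 nM, with a range from 8000 nM to 60000 nM. The step of a 2.1-fold higher number from compound 1 to compound 4 (0.31 log units; beyond the scatter) is the expected outcome.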

Compound 4, half-maximal inhibitory concentration: 15700 nM
Estimate against measurement, compound 4: 1.4-fold (0.15 log units) above, within the range that was stated.
By their numbers in this assay, from the lowest: compounds 1, 4, 3 and 2 (each within the scatter of the next, the first and the last beyond it).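

At the carbon with a double bond to nitrogen, 4-(diethylamino)-2-hydroxyphenyl brings a hydrogen-bond donor and hydrogen-bond acceptors that 3-bromophenyl lacks, yet in this assay the swap gives only a 1.5-fold higher number from compound 1 to compound 4 (0.17 log units; within the scatter). The same group also stays within the scatter of the other two aryl groups, with a 1.7-fold lower number from compound 3 to compound 4 (0.24 log units; within the scatter) and a 1.9-fold lower number from compound 2 to compound 4 (0.27 log units; within the scatter), so compound 4 bridges the gap that separated compound 1 from compound 2 and compound 3, and the four compounds do not divide into clear groups. No available measurement explains these values.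

The compounds shown do not separate the diethylamino part of the entering group from its hydroxyl. They also leave open how this position responds to a non-aromatic group such as cyclohexyl, or to a phenyl bearing a carboxylic acid.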